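The compounds below may be only part of what the source reports. "The series", "measured", "known", "first", "only" and "open" are said of these compounds alone.

compound 1 `O=C(CCCCC1CCSS1)Nc1ccc(OC(F)(F)F)cc1`: 20.3%
compound 2 `O=C(CCCCC(S)CCS)Nc1ccc(F)cc1`: 18.1%

In a functional assay on NCI-H460 cells (Homo sapiens) for inhibition, read by MTT assay, with a stated time of 24 h, tested at 10 ug/mL (on this read-out lower numbers stand for less inhibition of growth and higher numbers for more inhibition of growth at the one concentration tested), compound 2 gives 18.1% and compound 1 gives 20.3%, so the two stand within the usual scatter of each other. Both numbers show modest inhibition of growth at the one concentration tested.

The next compound is compound 3 `O=C(CCCCC(S)CCS)Nc1ccc(OC(F)(F)F)cc1`, which has trifluoromethoxy in place of fluoro on an aromatic carbon, para to a large group: trifluoromethoxy in place of fluoro on an aromatic carbon.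

Among the measured compounds shown here, no two measured compounds differ in one place only, so the data give no direct size for a step of this kind. For the measured compounds named here, with only two values in hand, no step beyond the scatter is expected in this assay, and no direction is favoured. The expected change is a number 1.9 percentage points higher from compound 2 to compound 3 (within the scatter).

The estimated value for compound 3 is 20%, with an expected range from 8% to 35%.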

Compound 3, percent growth inhibition at one concentration: 29.2%
Compound 3: middle estimate off by 9.2 percentage points, on the low side; measured number inside the range.
By their numbers in this assay, from the lowest: compounds 2, 1 and 3 (each within the scatter of the next, the first and the last beyond it).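

In this assay, among the compounds shown here, trifluoromethoxy in place of fluoro on an aromatic carbon, para to a large group, gives a number 11.1 percentage points higher from compound 2 to compound 3 (beyond the scatter) and so provides the only step beyond the usual scatter, though a modest one. With trifluoromethoxy present in both compounds, the open chain in place of the five-membered non-aromatic ring gives a number 8.9 percentage points higher from compound 1 to compound 3 (within the scatter) and stays within the scatter, so this assay does not separate the two forms at this level of inhibition.

The compounds shown leave open how a methoxy, chloro or trifluoromethyl group would read at the same aromatic carbon. They also leave open whether the step from fluoro to trifluoromethoxy would persist with the five-membered ring in place of the open chain, or with a longer chain. No measurement at hand explains the step at the aromatic carbon.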